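This account rests on a few compounds, and the source may have more. Where it says the series, first, only, none or still open, it means among the compounds named here.

Measured so far in a functional assay on the whole organism (strain Wistar) for inhibition, with Rattus norvegicus as the target, read by paw edema, with a stated time of 3 h, at a dose of 10 mg/kg by the intraperitoneal route; a higher number here means more inhibition at the dose given (going by the name of the read-out), a lower number less inhibition:

- compound 1, `O=C(N/N=C/c1cccc(F)c1)c1cccnc1Nc1cccc(C(F)(F)F)c1`: 37%
- compound 2, `O=C(N/N=C/c1ccc(F)cc1)c1cccnc1Nc1cccc(C(F)(F)F)c1`: 41.3%
- compound 3, `O=C(N/N=C/c1ccc(Cl)cc1)c1cccnc1Nc1cccc(C(F)(F)F)c1`: 48.5%

Compound 1 gives the lowest of the three numbers. Its nearest neighbour is compound 2, and the step of a number 4.3 percentage points higher from compound 1 to compound 2 (within the scatter) stays within the scatter, so the two cannot be ranked. The step of a number 11.5 percentage points higher from compound 1 to compound 3 (beyond the scatter) is beyond the scatter, though modest. Between compound 2 and compound 3 the step of a number 7.2 percentage points higher from compound 2 to compound 3 (within the scatter) is again within the scatter.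

The unmeasured compound 4 has the structure `CN(C)c1ccc(/C=N/NC(=O)c2cccnc2Nc2cccc(C(F)(F)F)c2)cc1`. It differs from compound 1 in one place: 4-(dimethylamino)phenyl in place of 3-fluorophenyl on a carbon with a double bond to nitrogen. Among the compounds with values here, two measured steps bear on this. The step of a number 4.3 percentage points higher from compound 1 to compound 2 (within the scatter) shows what moving a single small substituent to the position of the new group does, and the step of a number 11.5 percentage points higher from compound 1 to compound 3 (beyond the scatter) shows what a different single substituent at that position does. Nothing measured speaks to a dimethylamino group itself. The expectation for compound 4 in this assay is therefore a step of about a number 8 percentage points higher from compound 1 to compound 4 (within the scatter), upward but small, possibly not beyond the scatter. Compound 4 is estimated at 45%, with a range from 30% to 60%.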

Compound 4, a percentage reported as inhibition, in the whole organism at one dose (the size of the read-out at that dose, not a potency): 39.5%
Compound 4: the middle estimate sits 5.5 percentage points above what was measured, within the range that was stated.
By their numbers in this assay, from the lowest: compounds 1, 4, 2 and 3 (each within the scatter of the next, the first and the last beyond it).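

Within the data shown here, the 4-(dimethylamino)phenyl group is the first at this position to carry a hydrogen-bond acceptor, yet in this assay it gives only a number 2.5 percentage points higher from compound 1 to compound 4 (within the scatter), so this larger change in the group does not separate the two compounds. Swapping the substituent on the aromatic carbon gives a number 1.8 percentage points lower from compound 2 to compound 4 (within the scatter) for dimethylamino in place of fluoro and a number 9 percentage points lower from compound 3 to compound 4 (within the scatter) for dimethylamino in place of chloro, so compound 4 cannot be ranked against any of the other three, even though compound 1 and compound 3 lie beyond the scatter of each other. No measurement shown here explains these numbers.

As far as these compounds go, it remains open whether a carboxylic acid or a primary amine in place of the dimethylamino group would give a step beyond the scatter. The compounds shown also leave open whether a methoxy group would.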